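A few compounds are considered here, and "the series" means these few. Any claim that something is new, unique, unknown or untested is made for them only; others in the source may bear on it.

Of the compounds shown here, three on the shared core have values so far. In a functional assay on PC-9 cells (Homo sapiens) for inhibition, read by MTT assay, with a stated time of 72 h (a lower number here means a stronger inhibitor, a higher number a weaker inhibitor), compound 1 `Cc1cc(Nc2cc(-c3ccccc3)[nH]n2)n2nc(SCc3c(Cl)cccc3Cl)nc2n1` gives 5180 nM and compound 2 `Cc1cc(Nc2cc(-c3ccccc3)[nH]n2)n2nc(SCc3ccccc3Br)nc2n1` gives 5630 nM. Exchanging the two substituted phenyl groups is a 1.1-fold higher number from compound 1 to compound 2 (0.04 log units; within the scatter).

Compound 3 `C#CCSc1nc2nc(C)cc(Nc3cc(-c4ccccc4)[nH]n3)n2n1` gives > 50000 nM in this assay, which is a limit of the assay and not a number.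

Ethynyl in place of the phenyl groups gives an at least 9.6-fold higher number from compound 1 to compound 3 (0.98 log units; beyond the scatter) and an at least 8.8-fold higher number from compound 2 to compound 3 (0.94 log units; beyond the scatter).

Compound 4 `CCCSc1nc2nc(C)cc(Nc3cc(-c4ccccc4)[nH]n3)n2n1` carries ethyl in place of ethynyl on a saturated chain carbon bound to a sulfur, which also reads as propyl in place of propargyl: ethyl in place of ethynyl on a saturated chain carbon bound to a sulfur.

Going by the values given here, no measured step exchanges one small chain for another, so the two steps to compound 3 bear on this change only indirectly. Compound 4 also lacks a phenyl group on the chain, and its loss came with an at least 8.8-fold higher number from compound 2 to compound 3 (0.94 log units; beyond the scatter). Only a small move towards a lower number in this assay is therefore expected, and a second limit would be no surprise.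

The estimate amounts to an expected at least 1.5-fold lower number from compound 3 to compound 4 (0.19 log units; that floor lies within the scatter).

For compound 4 the expected value is 32000 nM, with an estimated range of 15000 nM to 50000 nM.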

Compound 4, half-maximal inhibitory concentration: > 50000 nM
Compound 4: a limit, no number; the forecaster's own chance of this, stated with the estimate: 50%; at least 1.5-fold (0.19 log units) between middle value and limit.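

On a saturated chain carbon bound to a sulfur, the change from ethynyl to ethyl yields no readable difference in this assay: the step from compound 3 to compound 4 cannot be read, because both compounds sit at a limit of the assay and neither gives a number: the limit of > 50000 nM in this assay, at which 2 of the 4 values shown sit.

The drop against the substituted phenyl groups no longer rests on compound 3 alone, since ethyl in place of 2-bromophenyl gives an at least 8.8-fold higher number from compound 2 to compound 4 (0.94 log units; beyond the scatter), and ethyl in place of 2,6-dichlorophenyl gives an at least 9.6-fold higher number from compound 1 to compound 4 (0.98 log units; beyond the scatter). Among the compounds shown, the triple bond is therefore not needed for this move to a higher number, which appears with the propargyl and the propyl chain alike, and only compound 1 and compound 2 give a number.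

On these data alone, how far compound 3 and compound 4 lie past the limit stays open, so any difference between the two small chains remains hidden. Also open, as far as these compounds go, is whether an unsubstituted phenyl, a longer chain or an amine on this saturated chain carbon would give a number in this assay.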